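From compound 1 to compound 3: one methyl removed

A few compounds are considered here, and "the series" means these few. Any claim that something is new, unique, unknown or untested is made for them only; others in the source may bear on it.

Compound 1 `COc1ccc(-c2c(C)nc3c(N4CC[C@@H](NC(C)=O)C4)cc(C)nn23)cc1OC`: > 95%
Compound 2 `COc1ccc(-c2c(C)nc3c(N4CC[C@@H](NC(=O)Nc5ccccc5)C4)cc(C)nn23)cc1OC`: > 95%

In an ADME assay on microsomes from liver (Mus musculus) for metabolic stability, read by LC-MS, with NADPH named in the record, with a stated time of 60 min, tested at 1 uM, in the absence of a further agent (a higher number here means that more of the compound is left, a lower number that less of the compound is left), compound 1 gives > 95%, which is a limit and not a number. Compound 2 gives > 95%, which is also a limit. Both measured compounds therefore share one reading: the limit of > 95% in this assay, at which 2 of the 2 values shown sit. Within the data shown here, the only measured step, a step that the two limits leave unreadable from compound 1 to compound 2, has no readable size and concerns a different place in the molecule.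

Compound 3 `COc1ccc(-c2cnc3c(N4CC[C@@H](NC(C)=O)C4)cc(C)nn23)cc1OC` differs from compound 1 in one place: hydrogen in place of methyl on an aromatic carbon. Among the measured compounds shown here, no measured step touches this aromatic carbon, so the expectation is uncertain. It rests on compound 1, whose > 95% is a limit, so only a lower reading could reveal a step. The expected change is small and downward, and may stay within the scatter: a number at least 5 percentage points lower from compound 1 to compound 3 (that floor lies within the scatter). For compound 3 the estimated value is 90%, with an expected range from 72% to 100%.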

Compound 3, percent of the compound remaining: > 95%
Compound 3: a limit, no number (the forecaster's own chance of this, stated with the estimate: 50%); at least 5 percentage points between middle value and limit.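

In this assay compound 3 gives > 95%, which is a limit and not a number. No step can be read between compound 1 and compound 3, and all the compounds share one reading: the limit of > 95% in this assay, at which 3 of the 3 values shown sit.

The compounds shown leave open whether losing this methyl changes how much compound remains.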